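A Nitrile Tail Added to a Series Without Cytotoxicity

This account rests on a few compounds, and the source may have more. Where it says the series, first, only, none or still open, it means among the compounds named here.

Compound 1, `CCCCn1nc(C(=O)N[C@H]2COc3ccccc3N(C)C2=S)nc1Cc1ccccc1`, was examined in a toxicity assay on HT-29 cells (Homo sapiens) for cytotoxicity; a higher number here means that more compound is tolerated, a lower number that less compound is tolerated. There compound 1 gives > 100000 nM, which is a limit of the assay and not a number. Compound 2, `CCCCCn1nc(C(=O)N[C@H]2COc3ccccc3N(C)C2=S)nc1Cc1ccccc1`, gives > 100000 nM, again a limit. Compound 3, `COCCn1nc(C(=O)N[C@H]2COc3ccccc3N(C)C2=S)nc1Cc1ccccc1`, gives > 100000 nM, also a limit. All three share the same limit, (the limit of > 100000 nM in this assay, at which 3 of the 3 values shown sit), so the steps among them cannot be read: a step that the two limits leave unreadable from compound 1 to compound 2, a step that the two limits leave unreadable from compound 1 to compound 3 and a step that the two limits leave unreadable from compound 2 to compound 3 are all of unreadable size.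

Compound 4, `CN1C(=S)[C@@H](NC(=O)c2nc(Cc3ccccc3)n(CCCCCC#N)n2)COc2ccccc21`, differs from compound 1 by cyanomethyl in place of hydrogen on a saturated chain carbon, four bonds along the chain from an aromatic nitrogen. The closest measured step is a step that the two limits leave unreadable from compound 1 to compound 2, in which a methyl also entered four bonds along the chain from the aromatic nitrogen, and compound 2 stayed at the limit. With no readable step anywhere, the expected step is a step that the limit leaves unreadable from compound 1 to compound 4, nothing beyond the scatter. Compound 4 is therefore expected to give 200000 nM, with a range from 60000 nM to 700000 nM, most likely reported once more only as a limit.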

Compound 4, half-maximal cytotoxic concentration: > 100000 nM
Compound 4: a limit, no number; the forecaster's own chance of this, stated with the estimate: 85%; the middle value does not contradict the limit.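

Compound 4 gives > 100000 nM as a limit of the assay and not a number. Its steps with compound 1, compound 2 and compound 3 therefore cannot be read: the limit of > 100000 nM in this assay, at which 4 of the 4 values shown sit.

The compounds shown leave open whether any chain on the shared core gives a readable value in this assay at all.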